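The source may report more compounds than this note shows. Statements on the series, on what has been measured and on what is new or still open speak of the compounds shown alone.

The measured compounds in an ADME assay on Vero cells (Chlorocebus sabaeus) for cytotoxicity, read by MTT assay; a higher number here means a weaker inhibitor, a lower number a stronger inhibitor:

compound 1, `CCCCCC(=O)OCC(C)(C)CC1=C(O)C(=O)c2ccccc2C1=O`: 169000 nM
compound 2, `CCCCCCCC(=O)OCC(C)(C)CC1=C(O)C(=O)c2ccccc2C1=O`: > 258000 nM; this is a limit of the assay, not a number
compound 3, `CCCCCCCCCCCC(=O)OCC(C)(C)CC1=C(O)C(=O)c2ccccc2C1=O`: 249000 nM

All three share the core of compound 1 and differ only in the ester chain. From compound 1 to compound 2 the change is ethyl in place of hydrogen on a saturated chain carbon, five bonds along the chain from a carbonyl carbon; in this assay it gives an at least 1.5-fold higher number from compound 1 to compound 2 (0.18 log units; that floor lies within the scatter), and compound 1 also stands against compound 3 with a 1.5-fold higher number from compound 1 to compound 3 (0.17 log units; within the scatter). Compound 3 and compound 2 show an at least 1.0-fold lower number from compound 2 to compound 3 (0.01 log units; that floor lies within the scatter). One value sits at the limit of > 258000 nM in this assay, at which 1 of the 3 values shown sits.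

The unmeasured compound 4, `CCCCCCCCCCCCCC(=O)OCC(C)(C)CC1=C(O)C(=O)c2ccccc2C1=O`, arises from compound 3 by ethyl in place of hydrogen on a saturated chain carbon, ten or more bonds along the chain from a carbonyl carbon. The core of compound 3 differs from that of compound 1 by hexyl in place of hydrogen on a saturated chain carbon, five bonds along the chain from a carbonyl carbon, so the change to compound 4 is the same kind of change as that from compound 1 to compound 2, only at the place on the chain that the difference itself names. Since compound 3 gives 249000 nM and the earlier step was an at least 1.5-fold higher number from compound 1 to compound 2 (0.18 log units; that floor lies within the scatter), a step of about a 1.0-fold higher number from compound 3 to compound 4 (0.02 log units; within the scatter) is expected. Compound 4 is therefore estimated at 260000 nM, between 150000 nM and 420000 nM.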

Compound 4, half-maximal inhibitory concentration: 58400 nM
Compound 4: middle estimate off by 4.5-fold (0.65 log units), on the high side, and the stated range ends above it.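

In this assay, ethyl in place of hydrogen on a saturated chain carbon did not carry from one core to the other, and the step depended on where along the chain it fell: the same change on two cores in this assay, an at least 1.5-fold higher number (0.18 log units; that floor lies within the scatter) from compound 1 to compound 2 and a 4.3-fold lower number (0.63 log units; beyond the scatter) from compound 3 to compound 4, at least 6.5-fold (0.81 log units) apart, beyond the scatter of two such steps. Compound 4 separates from the shorter esters with a 4.3-fold lower number from compound 3 to compound 4 (0.63 log units; beyond the scatter) and an at least 4.4-fold lower number from compound 2 to compound 4 (0.64 log units; beyond the scatter) and a 2.9-fold lower number from compound 1 to compound 4 (0.46 log units; beyond the scatter), and hexyl in place of hydrogen shows the same lack of transfer: the same change on two cores in this assay, a 1.5-fold higher number (0.17 log units; within the scatter) from compound 1 to compound 3 and an at least 4.4-fold lower number (0.64 log units; beyond the scatter) from compound 2 to compound 4, at least 6.5-fold (0.81 log units) apart, beyond the scatter of two such steps. The value of compound 2, > 258000 nM, is a limit of the assay and not a number, and these steps show a difference in size without showing what lies behind it.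

From the compounds shown here alone, how a chain longer than that of compound 4 would read in this assay remains open, and with only these four esters it cannot be said whether the lower number would persist. An amide in place of the ester, or a branched chain, also remains untested among the compounds shown.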